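The source may hold more compounds than are shown below. What is called first, only, known or untested is meant among the compounds shown, and "the series" means these compounds.

In a functional assay on the whole organism (Tail, strain ICR) with Mus musculus as the target, in the tail flick test, with a stated time of 60 min, at a dose of 25 umol/kg by the oral route (a lower number here means a weaker effect, a higher number a stronger effect of the compound at the dose given), the measured compounds stand as follows: compound 1 `CSCC[C@H](NC(=O)CN(c1nc(Cl)nc2[nH]cnc12)C1CC1)C(=O)OCc1ccccc1` gives 30.8%; compound 2 `O=C(CN(c1nc(Cl)nc2[nH]cnc12)C1CC1)N[C@@H](CC(=O)OCc1ccccc1)C(=O)OCc1ccccc1` gives 22.4%; compound 3 `NCCCC[C@H](NC(=O)CN(c1nc(Cl)nc2[nH]cnc12)C1CC1)C(=O)OCc1ccccc1` gives 41.2%.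

Compound 3 holds the highest of the three numbers, and both of its steps lie beyond the scatter: a number 10.4 percentage points higher from compound 1 to compound 3 (beyond the scatter) and a number 18.8 percentage points higher from compound 2 to compound 3 (beyond the scatter). Compound 4 `CC[C@H](C)[C@H](NC(=O)CN(c1nc(Cl)nc2[nH]cnc12)C1CC1)C(=O)OCc1ccccc1` differs from compound 3 as follows: sec-butyl in place of 4-aminobutyl on a saturated chain carbon bound to an amide-type nitrogen and a carbonyl carbon. Both steps that reached compound 3 brought in an amino-bearing chain and raised the read-out by a modest amount; compound 4 removes that chain again. A modest fall in this assay is therefore expected, a number 13.2 percentage points lower from compound 3 to compound 4 (beyond the scatter), landing near compound 1. Compound 4 is estimated at 28%, within a range of 15% to 42%.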

Compound 4, a percentage reported as activity, at one dose (the size of the read-out at that dose, not a potency): 40.6%
For compound 4 the middle estimate is 12.6 percentage points below the measured one, within the range that was stated.
By their numbers in this assay, from the lowest: compounds 2, 1, 4 and 3 (each within the scatter of the next, the first and the last beyond it).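

In this assay, the amino group of the chain turns out not to be needed at this position: sec-butyl, with no hydrogen-bond donor, replaces 4-aminobutyl with a number 0.6 percentage points lower from compound 3 to compound 4 (within the scatter) at this carbon. Set against the other side chains, sec-butyl gives a number 18.2 percentage points higher from compound 2 to compound 4 (beyond the scatter) against (benzyloxycarbonyl)methyl and a number 9.8 percentage points higher from compound 1 to compound 4 (within the scatter) against 2-(methylsulfanyl)ethyl, so a branched hydrocarbon chain serves here as well as the amine. Nothing at hand explains this result in any way. As far as these compounds go, whether a free carboxylic acid or a simple methyl on this carbon would keep the read-out remains open.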